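Swapping Carboxy for Sulfamoyl on an Inactive Compound

The source may hold more compounds than are shown below. What is called first, only, known or untested is meant among the compounds shown, and "the series" means these compounds.

In a functional assay, read by spectrophotometry, with a stated time of 1 h (a higher number here means a weaker inhibitor, a lower number a stronger inhibitor), compound 1 `CCCC/N=C/c1cc2cc(C)ccc2[nH]c1=O` gives 3560000 nM. Compound 2 `O=C(O)c1ccc(/N=C/c2cc3ccccc3[nH]c2=O)cc1` has no single number, and its entry reads "not active" (no number reported). Compound 3 `Cc1ccc2[nH]c(=O)c(/C=N/c3ccc(C(=O)O)cc3)cc2c1` also lacks a number, and its entry reads "not active" (no number reported). Compound 2 therefore offers no value from which to measure a change.

Compound 4 `NS(=O)(=O)c1ccc(/N=C/c2cc3ccccc3[nH]c2=O)cc1` differs from compound 2 by having sulfamoyl in place of carboxy on an aromatic carbon. For the measured compounds named here, no measured step shows what this swap does. A large step towards stronger inhibition in this assay is expected, although compound 4 may also end up without a number. The estimated value for compound 4 is 10000 nM, with an expected range of 100 nM to 1000000 nM.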

Compound 4, half-maximal inhibitory concentration: 266000 nM
The estimate for compound 4 lay 27-fold (1.42 log units) below the measured number; the measured number falls inside the stated range.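

For the compounds shown here, compound 2 is recorded as "not active" with no number, so no step to compound 4 can be read. Going by these compounds, what swapping carboxy for sulfamoyl does in size in this assay stays open. Nothing shown here explains the result.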